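The compounds below may be only part of what the source reports. "The series", "measured", "known", "first", "only" and "open" are said of these compounds alone.

Series notes, aryloxy-imidazoline type, read in a functional assay on CHO cells for agonist activity at Alpha-2C adrenergic receptor (Homo sapiens); on this read-out higher numbers stand for larger maximal responses and lower numbers for smaller maximal responses.

Compound 1 `CC(Oc1ccccc1-c1ccc([N+](=O)[O-])cc1)C1=NCCN1` carries a nitrophenyl group on the shared core. In this assay compound 1 gives only a limit, < 0.3. Compound 2 `CC(Oc1ccccc1-c1ccncc1)C1=NCCN1` bears pyridin-4-yl in the same place. In this assay compound 2 likewise gives only a limit, < 0.3. Compound 3 `CC(Oc1ccccc1-c1ccccc1)C1=NCCO1` has a plain phenyl group and an oxazoline in place of the imidazoline. In this assay compound 3 also gives only a limit, < 0.3. Compound 2 therefore stands where every measured member of the series stands, at the limit of < 0.3 in this assay, at which 3 of the 3 values shown sit, so no ordering among the three can be drawn.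

Compound 4 `CC(Oc1ccccc1-c1ccccn1)C1=NCCN1` is unmeasured. It differs from compound 2 by pyridin-2-yl in place of pyridin-4-yl on an aromatic carbon. For the measured compounds named here, no measured pair differs in one place, so the size of this step cannot be read from neighbours; with all three known values sitting at the limit, no shift beyond the scatter is expected, and the step from compound 2 to compound 4 is estimated as a step that the limit leaves unreadable from compound 2 to compound 4. Compound 4 is expected to give about 0.2, most likely again reported as a limit, within 0.05 to 0.4.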

Compound 4, intrinsic activity: the largest response reached, as a fraction of the reference agonist's: < 0.3
Compound 4 was reported as a limit; the forecaster's own chance of this, stated with the estimate: 75%; the middle value is on the limit's open side.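

Compound 2 and compound 4 are both reported only as limits, so no step can be read between pyridin-4-yl and pyridin-2-yl: the limit of < 0.3 in this assay, at which 4 of the 4 values shown sit.

The compounds shown leave open whether any change on the shared core lifts the maximal response in this assay clear of that limit.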